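Cytotoxicity of Acid and Ester Amide Analogues

The source may report more compounds than this note shows. Statements on the series, on what has been measured and on what is new or still open speak of the compounds shown alone.

Measured compounds:
compound 1 `CC(C)N(Cc1cccc(OCCCCCC(=O)O)c1)C(=O)c1ccc(-c2ccc3cc[nH]c3c2)cc1` — > 26000 nM
compound 2 `COc1cc(OC)cc(-c2ccc(C(=O)N(Cc3cccc(OCCCCCC(=O)O)c3)C(C)C)cc2)c1` — > 26000 nM
compound 3 `CCOC(=O)CCCCCOc1cccc(CN(C(=O)c2ccc(-c3ccc4cc[nH]c4c3)cc2)C(C)C)c1` — > 26000 nM

In an ADME assay on BJ cells (Homo sapiens) for cytotoxicity, read by CellTiter-Glo and resazurin assay, with a stated time of 72 h (a lower number here means that less compound is needed, a higher number that more compound is needed for the effect), compound 1 gives > 26000 nM, which is a limit of the assay and not a number. In this assay compound 2 gives > 26000 nM, likewise a limit. In this assay compound 3 gives > 26000 nM, again only a limit. Between compound 1 and compound 2 the change is 3,5-dimethoxyphenyl in place of 1H-indol-6-yl on an aromatic carbon. Between compound 1 and compound 3 the change is ethyl in place of hydrogen on an oxygen next to a carbonyl group. The size of neither step can be read, a step that the two limits leave unreadable from compound 1 to compound 2 and a step that the two limits leave unreadable from compound 1 to compound 3, because of the limit of > 26000 nM in this assay, at which 3 of the 3 values shown sit.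

Compound 4 `CCOC(=O)CCCCCOc1cccc(CN(C(=O)c2ccc(-c3cc(OC)cc(OC)c3)cc2)C(C)C)c1` has not yet been measured in this assay. It differs from compound 3 by 3,5-dimethoxyphenyl in place of 1H-indol-6-yl on an aromatic carbon, and this is the same change that was made from compound 1 to compound 2, with the place described in the same words both times. The two cores differ as described for compound 1 and compound 3.

For compound 4 the step that the limit leaves unreadable from compound 3 to compound 4 is expected to be small, resting on compound 1 with > 26000 nM and on compound 2 with > 26000 nM, where the same change left the value at a limit. Compound 4 is therefore estimated at 40000 nM, with the range 20000 nM to 120000 nM, and most probably only a limit will be reported.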

Compound 4, half-maximal effective concentration: > 26000 nM
Compound 4: only a limit was reported; the forecaster's own chance of this, stated with the estimate: 85%; the middle value is on the limit's open side.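

The steps from compound 3 to compound 4 and from compound 2 to compound 4 cannot be sized, because each comparison ends at the same limit, which is not a number: the limit of > 26000 nM in this assay, at which 4 of the 4 values shown sit.

The compounds shown leave open at what concentration, if any, each would reach the half-maximal effect in this assay, and whether swapping 1H-indol-6-yl for 3,5-dimethoxyphenyl or adding the ethyl group changes that concentration.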